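Series notes: aryl swap on the carbonyl carbon

The source may report more compounds than this note shows. Statements on the series, on what has been measured and on what is new or still open speak of the compounds shown alone.

For the measured compounds named here, compound 1 `COc1cc(-c2cc(/C=C/C(=O)c3ccc(N)cc3)[nH]n2)cc(OC)c1OC` is the only member of the set with a number: in a functional assay on LOX IMVI cells (Homo sapiens) for inhibition, read by sulforhodamine B assay, with a stated time of 48 h (on this read-out lower numbers stand for stronger inhibition of growth and higher numbers for weaker inhibition of growth), compound 1 gives 1060 nM. Compound 2 `COc1ccc(-c2cc(/C=C/C(=O)c3ccc(OC)c(OC)c3)[nH]n2)cc1` is a further member, and in this assay compound 2 shows "not determined" (no result reported). Compound 3 `COc1cc(-c2cc(/C=C/C(=O)c3ccc(Cl)c(Cl)c3)[nH]n2)cc(OC)c1OC` differs from compound 1 by 3,4-dichlorophenyl in place of 4-aminophenyl on a carbonyl carbon. Going by the values given here, no measured pair with a single change exists to calibrate this swap, so the expected step of a 1.4-fold higher number from compound 1 to compound 3 (0.15 log units; within the scatter) in this assay is small, with no firm direction expected beyond the usual scatter. Compound 3 is therefore estimated at 1500 nM, within a range from 400 nM to 6000 nM.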

Compound 3, concentration for 50% growth inhibition: 3390 nM
Estimate against measurement, compound 3: 2.3-fold (0.35 log units) below, and the stated range covers the measured number.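

In this assay, for the compounds shown here, this place on the carbonyl carbon responds to the aryl group: 3,4-dichlorophenyl in place of 4-aminophenyl gives a 3.2-fold higher number from compound 1 to compound 3 (0.50 log units; beyond the scatter) as the first measured single change here. The step is modest but beyond the scatter, and compound 1 holds the lower number of the pair. Nothing at hand accounts for this step.

The swap removes the amine and adds both chlorines at once, so their shares stay unseparated. A 4-chlorophenyl, 3-chlorophenyl or 4-hydroxyphenyl group at this place would help divide them.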